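The compounds below may be only part of what the source reports. "The series", "measured", "known", "first", "only" and "open" are said of these compounds alone.

Measured compounds in a functional assay on MCF7 cells (Homo sapiens) for cytotoxicity, read by MTT assay, with a stated time of 24 h; a lower number here means a stronger inhibitor, a higher number a weaker inhibitor:

- compound 1, `Cc1cc(O)c(C(=O)/C=C/c2ccc(Br)cc2)c(-c2ccccc2)c1C(=O)/C=C/c1ccc(Br)cc1`: 10000 nM
- compound 2, `Cc1cc(O)c(C(=O)/C=C/c2cccc(Cl)c2)c(-c2ccccc2)c1C(=O)/C=C/c1cccc(Cl)c1`: 20000 nM
- compound 3, `Cc1cc(O)c(C(=O)/C=C/c2ccc3ccccc3c2)c(-c2ccccc2)c1C(=O)/C=C/c1ccc2ccccc2c1`: 31500 nM

Compound 1 holds the lowest number of the three in this assay. Its gap to compound 2 is within the scatter, so the two cannot be ordered; only the gap to compound 3 lies beyond the scatter. Nothing further separates any pair of these compounds by a single change, so no measured step exists in the set.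

Compound 4, `Cc1cc(O)c(C(=O)/C=C/c2ccc(Br)cc2)c(-c2ccc(Br)cc2)c1C(=O)/C=C/c1ccc(Br)cc1`, differs from compound 1 in one place: bromo in place of hydrogen on an aromatic carbon. The rest of the shared core, with its two bromo-bearing enone arms, is unchanged.

Among the measured compounds shown here, no measured step speaks to a bromo entering a phenyl at that place. The expectation is therefore neutral: the step of a 1.1-fold lower number from compound 1 to compound 4 (0.05 log units; within the scatter) is expected to stay within the scatter, with no clear direction. Compound 4 is estimated at 9000 nM in this assay, within 3500 nM to 25000 nM.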

Compound 4, half-maximal inhibitory concentration: 15000 nM
Compound 4: middle estimate off by 1.7-fold (0.22 log units), on the low side; the measured number falls inside the stated range.
By their numbers in this assay, from the lowest: compounds 1, 4, 2 and 3 (each within the scatter of the next, the first and the last beyond it).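

In this assay, among the compounds shown here, the phenyl of the shared core is now varied for the first time, as compounds 1 to 3 differ only in their enone arms. The change from phenyl to 4-bromophenyl gives a 1.5-fold higher number from compound 1 to compound 4 (0.18 log units; within the scatter), so compound 1 and compound 4 cannot be ordered, and this place accepts a bromine atom with no readable shift in the number. No independent measurement bears on this result, so it stays an observation on these two compounds alone.

Going by these compounds, whether an amine or a carboxylic acid at this place would move the number beyond the scatter remains open. On these data alone, it is also open whether the bromo replacement would read the same with the enone arms of compound 2 or compound 3.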